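A few compounds are considered here, and "the series" means these few. Any claim that something is new, unique, unknown or untested is made for them only; others in the source may bear on it.

In a functional assay, read by spectrophotometry, with a stated time of 15 min (a lower number here means a stronger inhibitor, a higher number a weaker inhibitor), compound 2 `Cc1nc2c3ccccc3ccc2c2nc3c(ccc4ccccc43)c(-c3ccccc3S)c12` gives 49.6 ug/mL. Compound 1 `Cc1nc2c3ccccc3ccc2c2nc3c(ccc4ccccc43)c(-c3ccccc3Cl)c12` gives 74.6 ug/mL in this assay, and the step from it a 1.5-fold lower number from compound 1 to compound 2 (0.18 log units; within the scatter) leaves the two within the scatter of each other. Compound 3 `Cc1nc2c3ccccc3ccc2c2nc3c(ccc4ccccc43)c(C)c12` differs from compound 2 by methyl in place of 2-sulfanylphenyl on an aromatic carbon. For the measured compounds named here, the single measured step swapped one substituent on the phenyl ring rather than removing that ring, so it bears only loosely on this change; no measured pair tests the loss of the aryl group. The expected step is a 1.7-fold higher number from compound 2 to compound 3 (0.23 log units; within the scatter), a somewhat higher number, though not clearly beyond the scatter. Compound 3 is estimated at 85 ug/mL, between 35 ug/mL and 200 ug/mL.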

Compound 3, half-maximal inhibitory concentration: 89.6 ug/mL
The estimate for compound 3 lay 1.1-fold (0.02 log units) below the measured number; low and high end bracket the measured number.
By their numbers in this assay, from the lowest: compounds 2, 1 and 3 (each within the scatter of the next).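

In this assay, methyl in place of 2-sulfanylphenyl on this aromatic carbon gives a 1.8-fold higher number from compound 2 to compound 3 (0.26 log units; within the scatter), and methyl in place of 2-chlorophenyl gives a 1.2-fold higher number from compound 1 to compound 3 (0.08 log units; within the scatter). Removing the whole aryl ring, and not only changing its substituent, therefore stays within the scatter for both pairs. At this position, the assay does not separate methyl from either substituted phenyl. From the compounds shown here alone, whether an amine, a carboxylic acid or a longer chain on this carbon would move the number beyond the scatter remains open. Nothing measured here offers a reason for these small steps.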